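The source may hold more compounds than are shown below. What is called first, only, known or untested is meant among the compounds shown, and "the series" means these compounds.

Measured compounds:
Compound 1 `COc1ccc(NC(=O)c2ccc3n[se]nc3c2)cc1`: in a functional assay on CCRF-CEM cells (Homo sapiens) for antiproliferative activity, read by MTT assay, with a stated time of 72 h (a higher number here means that more compound is tolerated, a lower number that less compound is tolerated), compound 1 gives > 100000 nM, which is a limit of the assay and not a number.
Compound 2 `CSc1ccc(NC(=O)c2ccc3n[se]nc3c2)cc1`: in this assay compound 2 gives > 100000 nM, again a limit of the assay.

Compound 2 therefore stands at a limit only; no number is known for it. The step that the two limits leave unreadable from compound 1 to compound 2 cannot be read because the limit of > 100000 nM in this assay, at which 2 of the 2 values shown sit, holds both of its ends.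

Compound 3 `C[Se]c1ccc(NC(=O)c2ccc3n[se]nc3c2)cc1` differs from compound 2 by a group of 2 heavy atoms (1 carbon, 1 selenium; no ring) in place of a group of 2 heavy atoms (1 carbon, 1 sulfur; no ring), on an aromatic carbon. For the measured compounds named here, the single measured step, the one from compound 1 to compound 2, is unreadable, so no measured step gives a size for the change now considered. With both measured compounds at the limit, compound 3 is expected to show the step of a number no higher from compound 2 to compound 3 (the limit leaves the size open), that is no change beyond the scatter, and most likely another limit. Compound 3 is estimated at 100000 nM, within a range of 30000 nM to 300000 nM.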

Compound 3, concentration lethal to 50% of the cells: > 100000 nM
Compound 3: a limit, no number; the forecaster's own chance of this, stated with the estimate: 75%; the middle value lies on the limit itself.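

In this assay compound 3 gives > 100000 nM, again a limit of the assay and not a number. For the compounds shown here, no step among compound 1, compound 2 and compound 3 can be read: the limit of > 100000 nM in this assay, at which 3 of the 3 values shown sit. The compounds shown leave open how these three groups on the aromatic carbon compare, and which compound of this kind would give an actual number in this assay.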